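Triazole substituent swap and HepG2 cytotoxicity: compound 4

The compounds below may be only part of what the source reports. "The series", "measured", "known", "first", "only" and "open" are said of these compounds alone.

In an ADME assay on HepG2 cells (Homo sapiens) for cytotoxicity, read by MTT assay, with a stated time of 24 h (on this read-out lower numbers stand for higher toxicity in this test and higher numbers for lower toxicity in this test), compound 1 `Fc1ccc(-c2cn(-c3ccnc4cc(Cl)ccc34)nn2)cc1` gives > 3080000 nM, which is a limit of the assay rather than a number. Compound 2 `OCCCc1cn(-c2ccnc3cc(Cl)ccc23)nn1` gives 151000 nM in this assay. Compound 3 `CC(C)(O)c1cn(-c2ccnc3cc(Cl)ccc23)nn1` gives 442000 nM, the highest of the two numbers shown; the nearest number is that of compound 2, and the step is a 2.9-fold higher number from compound 2 to compound 3 (0.47 log units; beyond the scatter). Compound 4 `Clc1ccc2c(-n3cc(C4CCCCC4)nn3)ccnc2c1` differs from compound 3 by cyclohexyl in place of 1-hydroxy-1-methylethyl on an aromatic carbon. Within the data shown here, two measured steps bear on this change, both exchanges of the 4-fluorophenyl for a hydroxy-bearing group: an at least 20-fold lower number from compound 1 to compound 2 (1.30 log units; beyond the scatter) and an at least 6.9-fold lower number from compound 1 to compound 3 (0.84 log units; beyond the scatter). The starting point of both is the limit (the limit of > 3080000 nM in this assay, at which 1 of the 3 values shown sits). The change to compound 4 takes the hydroxy group away again and brings in a six-membered ring of carbon only, which runs in the direction of compound 1, so a step upward beyond the scatter is expected, with a real chance that this assay again returns only a limit. Compound 4 is expected at 1500000 nM, in the range 400000 nM to 5000000 nM. The expected step is a 3.4-fold higher number from compound 3 to compound 4 (0.53 log units; beyond the scatter).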

Compound 4, half-maximal cytotoxic concentration: > 3200 nM
Compound 4: a limit, no number; the forecaster's own chance of this, stated with the estimate: 40%; the middle value is on the limit's open side.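

In this assay compound 4 gives > 3200 nM and this is a limit, not a number, so the steps to it from compound 1, compound 2 and compound 3 cannot be read. Where cyclohexyl places compound 4 relative to compound 2 and compound 3 remains open.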